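The source may report more compounds than this note shows. Statements on the series, on what has been measured and on what is new or still open speak of the compounds shown alone.

Measured compounds:
- compound 1, `Cc1nc(-c2cc(C(F)(F)F)ccc2[C@H]2CCOc3cc(S(=O)(=O)Nc4ccncn4)ccc32)co1`: a physicochemical assay for lipophilicity (a higher number here means a more lipophilic compound, a lower number a more polar compound), gives no result, the value is recorded as "not determined" (no result reported)
- compound 2, `CN1CCN(c2cc(C(F)(F)F)ccc2[C@H]2CCOc3cc(S(=O)(=O)Nc4nccs4)ccc32)CC1`: in this assay compound 2 gives 2.1

Going by the values given here, only two compounds carry an entry, and only compound 2 carries a number. Compound 1 shares much of its build with compound 2, but no result was reported for it, so compound 2 stands alone as the single point of reference; nothing can be said about how the two compare. Among the compounds with values here, no step between two measured compounds exists here, so no measured change in this assay can be quoted.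

Compound 3, `O=S(=O)(Nc1nccs1)c1ccc2c(c1)OCC[C@@H]2c1ccc(C(F)(F)F)cc1-c1ccc(F)nc1`, is the next compound in line, and it differs from compound 2 in one place: 6-fluoropyridin-3-yl in place of 4-methylpiperazin-1-yl on an aromatic carbon. The rest of the shared core, the sulfonamide and the thiazole part, is kept unchanged.

With one exchange of a seven-atom group for another seven-atom group, the expectation for this assay is a clear upward step, well beyond the scatter of repeated measurements. Starting from compound 2 at 2.1, the step from compound 2 to compound 3 is estimated at a number 1.30 log units higher from compound 2 to compound 3 (beyond the scatter). For compound 3 the estimate in this assay is 3.4, within a range from 2.7 to 4.1.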

Compound 3, distribution coefficient: 3.2
Compound 3: the middle estimate sits 0.20 log units above what was measured, within the range that was stated.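

In this assay, placing 6-fluoropyridin-3-yl instead of 4-methylpiperazin-1-yl on this aromatic carbon gives a number 1.10 log units higher from compound 2 to compound 3 (beyond the scatter), the only measured step among the compounds shown. This shows that the group at this place, ortho to a large group and meta to a trifluoromethyl group, can shift the read-out of this assay by a large amount, even when the group that leaves and the group that enters have the same number of heavy atoms, with the shared core, the sulfonamide and the thiazole unchanged. No measurement at hand explains the size of this step.

The exchange alters several things at once, replacing a non-aromatic ring with two hetero atoms by an aromatic ring with one hetero atom and adding a fluorine, so a single step cannot show how much each change contributes; a plain phenyl ring, a pyridin-3-yl without fluorine or a piperidin-1-yl at this carbon would help to separate them. Also open, on these data alone, is whether the exchange would give a similar step with a group other than thiazole on the sulfonamide, such as a pyridine ring.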